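The source may report more compounds than this note shows. Statements on the series, on what has been measured and on what is new or still open speak of the compounds shown alone.

Compound 1 `O=C(NNc1ccnc2cc(Cl)ccc12)c1ccccc1/N=C/c1ccc(Cl)cc1` stands lowest of the three numbers in a physicochemical assay for lipophilicity, measured as octanol-water partition; on this read-out higher numbers stand for higher lipophilicity and lower numbers for lower lipophilicity: compound 1 gives 5.62. Compound 2 `O=C(NNc1ccnc2cc(Cl)ccc12)c1ccccc1/N=C/c1cccc(Cl)c1Cl` gives 6.1 and compound 3 `O=C(NNc1ccnc2cc(Cl)ccc12)c1ccccc1/N=C/c1ccc(Cl)c(Cl)c1` gives 6.22. The steps of a number 0.48 log units higher from compound 1 to compound 2 (beyond the scatter) and a number 0.60 log units higher from compound 1 to compound 3 (beyond the scatter) are both modest rises, while the step of a number 0.12 log units higher from compound 2 to compound 3 (within the scatter) stays within the scatter. Compound 4 `O=C(NNc1ccnc2cc(Cl)ccc12)c1ccccc1/N=C/c1cc2ccccc2nc1Cl` differs from compound 1 by 2-chloroquinolin-3-yl in place of 4-chlorophenyl on a carbon with a double bond to nitrogen. Among the compounds with values here, no measured step exchanges 4-chlorophenyl for 2-chloroquinolin-3-yl, so the two chloro-for-hydrogen steps from compound 1 are the only guide, and they point to a modest rise. The step from compound 1 to compound 4 is therefore expected to be a number 0.68 log units higher from compound 1 to compound 4 (beyond the scatter). Compound 4 is estimated at 6.3, with a range from 5.8 to 6.8.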

Compound 4, partition coefficient: 6
The estimate for compound 4 lay 0.30 log units above the measured number; the range from low to high includes it.
By their numbers in this assay, from the lowest: compound 1; then compounds 4, 2 and 3 (each within the scatter of the next).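

At this carbon with a double bond to nitrogen, 2-chloroquinolin-3-yl is the only group shown that brings an aromatic ring with a hetero atom, and in this assay the exchange gives a number 0.38 log units higher from compound 1 to compound 4 (beyond the scatter). Against the two dichlorophenyl groups, the same group gives a number 0.22 log units lower from compound 3 to compound 4 (within the scatter) and a number 0.10 log units lower from compound 2 to compound 4 (within the scatter), so the larger ring system does not set compound 4 apart from either. Nothing at hand gives a reason for these steps. The compounds shown leave open whether the ring nitrogen or the added ring size governs the step, and how an unsubstituted phenyl, a pyridyl ring or an amine would read at this carbon.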